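Benzylcyclopentyl amide replaces pyridinylmethyl in hydroxamic acid series

A few compounds are considered here, and "the series" means these few. Any claim that something is new, unique, unknown or untested is made for them only; others in the source may bear on it.

Compound 1 `CN(C)c1ccc(C(=O)N[C@@H](CCCCCC(=O)NO)C(=O)NCc2ccccc2)cc1`: 12000 nM
Compound 2 `CN(C)c1ccc(C(=O)N[C@@H](CCCCCC(=O)NO)C(=O)NCc2ccccn2)cc1`: 33000 nM

Of the compounds shown here, two have been measured in a functional assay on NFF cells (Homo sapiens) for antiproliferative activity; on this read-out lower numbers stand for stronger inhibition and higher numbers for weaker inhibition. Within the data shown here, compound 2 gives the higher of the two numbers, and the only measured step leading to it is a 2.8-fold higher number from compound 1 to compound 2 (0.44 log units; beyond the scatter). Compound 3 `CN(C)c1ccc(C(=O)N[C@@H](CCCCCC(=O)NO)C(=O)NC2(Cc3ccccc3)CCCC2)cc1` has not been measured. It differs from compound 2 in one place: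

1-benzylcyclopentyl in place of (pyridin-2-yl)methyl on an amide-type nitrogen

Among the measured compounds shown here, the one measured step that bears on this change is the same a 2.8-fold higher number from compound 1 to compound 2 (0.44 log units; beyond the scatter), since the pyridin-2-yl that raised the number in compound 2 is removed again, and a phenyl returns on a benzyl. For the measured compounds named here, the cyclopentyl that enters on the amide-type nitrogen has no measured counterpart here, so its effect is unknown. On that basis the step is expected to run back toward the number of compound 1, and compound 3 is estimated at 10000 nM, within 3000 nM to 40000 nM, an expected step of a 3.3-fold lower number from compound 2 to compound 3 (0.52 log units; beyond the scatter).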

Compound 3, half-maximal inhibitory concentration: 3000 nM
For compound 3 the middle estimate is 3.3-fold (0.52 log units) above the measured one, within the range that was stated.
By their numbers in this assay, from the lowest: compound 3; then compound 1; then compound 2.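

In this assay, among these compounds, 1-benzylcyclopentyl in place of (pyridin-2-yl)methyl on the amide-type nitrogen gives an 11-fold lower number from compound 2 to compound 3 (1.04 log units; beyond the scatter) and is the largest step so far. Among the compounds shown here, the only earlier change at this position, pyridin-2-yl in place of phenyl, had raised the number, whereas compound 3 falls beyond the level of compound 1. Compound 1 and compound 3 both carry the phenyl. The step of a 4.0-fold lower number from compound 1 to compound 3 (0.60 log units; beyond the scatter) shows that the gain does not depend only on removing the ring nitrogen of compound 2.

No evidence is available to explain this gain. From the compounds shown here alone, it remains open whether a cyclopropyl or cyclohexyl ring would serve in place of the cyclopentyl, and whether a pyridin-2-yl in place of the phenyl of 1-benzylcyclopentyl would keep the lower number.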